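A few compounds are considered here, and "the series" means these few. Any claim that something is new, unique, unknown or untested is made for them only; others in the source may bear on it.

Series notes, ester variation on a shared core. Compound 1 `Cc1ccc(C(=O)OC2(C(=O)Nc3ccc([N+](=O)[O-])cc3)CCCCC2)cc1` carries a 4-methylphenyl group on the ester carbonyl carbon; in a functional assay on MCF7 cells (Homo sapiens) for inhibition, read by MTT assay, with a stated time of 72 h (on this read-out higher numbers stand for weaker inhibition and lower numbers for stronger inhibition), compound 1 gives 9.8 nM. Compound 2 `COc1ccc(C(=O)OC2(C(=O)Nc3ccc([N+](=O)[O-])cc3)CCCCC2)cc1` has methoxy in place of methyl on an aromatic carbon, and compound 2 gives 41.2 nM, the step being a 4.2-fold higher number from compound 1 to compound 2 (0.62 log units; beyond the scatter). Compound 3 `O=COC1(C(=O)Nc2ccc([N+](=O)[O-])cc2)CCCCC1` keeps only hydrogen on the ester carbonyl carbon, and compound 3 gives 35.4 nM. Among the three numbers compound 3 and compound 2 lie within the scatter of each other (a 1.2-fold lower number from compound 2 to compound 3 (0.07 log units; within the scatter)), while compound 1 stands apart: a 3.6-fold higher number from compound 1 to compound 3 (0.56 log units; beyond the scatter).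

Compound 4 `O=C(OC1(C(=O)Nc2ccc([N+](=O)[O-])cc2)CCCCC1)C(O)c1ccccc1` differs from compound 3 by hydroxy(phenyl)methyl in place of hydrogen on a carbonyl carbon. The measured steps that bear on this are the two that exchange an aryl group on the same carbonyl carbon for hydrogen: a 3.6-fold higher number from compound 1 to compound 3 (0.56 log units; beyond the scatter) and a 1.2-fold lower number from compound 2 to compound 3 (0.07 log units; within the scatter). Putting a group back onto this carbon therefore undid either a modest step or none. Hydroxy(phenyl)methyl is neither of the two aryl groups already tried, so the direction is read from those two steps only. The step expected in this assay is a 1.8-fold lower number from compound 3 to compound 4 (0.25 log units; within the scatter), a modest move toward a lower number or none beyond the scatter. For compound 4 the estimate is 20 nM, with a range from 7 nM to 60 nM.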

Compound 4, half-maximal inhibitory concentration: 5.01 nM
Compound 4: middle estimate off by 4.0-fold (0.60 log units), on the high side; the measured number lies below the stated range.
By their numbers in this assay, from the lowest: compounds 4 and 1 (each within the scatter of the next); then compounds 3 and 2 (each within the scatter of the next).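

In this assay the ester carbonyl carbon now gives a step beyond the scatter with a group whose ring is not attached directly to it: hydroxy(phenyl)methyl in place of hydrogen gives a 7.1-fold lower number from compound 3 to compound 4 (0.85 log units; beyond the scatter) on this read-out. The same group in place of 4-methoxyphenyl gives an 8.2-fold lower number from compound 2 to compound 4 (0.92 log units; beyond the scatter) and, since 4-methoxyphenyl stands within the scatter of hydrogen, the number depends on which group sits on this carbon and not merely on a group being there, with compound 2 going against any reading that a larger group alone lowers the number. In place of 4-methylphenyl, hydroxy(phenyl)methyl gives a 2.0-fold lower number from compound 1 to compound 4 (0.29 log units; within the scatter) and this step lies within the scatter, so two differently built groups reach the same range at this position.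

Which part of hydroxy(phenyl)methyl carries the step stays open, and a plain benzyl group or an aminomethyl group bearing the phenyl ring on the same carbonyl carbon would separate the hydroxy from the ring. No measurement to hand explains why these groups give these numbers.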